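Compound 2 to compound 4: hydroxy for trifluoromethyl

The source may report more compounds than this note shows. Statements on the series, on what has been measured and on what is new or still open speak of the compounds shown alone.

Of the compounds shown here, three sharing one core have been measured in a functional assay on HaCaT cells (Homo sapiens) for inhibition, read by sulforhodamine B assay, with a stated time of 48 h (a higher number here means a weaker inhibitor of growth, a lower number a stronger inhibitor of growth), so far. Compound 1 (`CC1(/C=C/c2ccccc2)C=CC(=O)O1`) stands at 119000 nM in this series. Compound 3 (`COc1cc(OC)c(/C=C/C2(C)C=CC(=O)O2)c(OC)c1`) stands at 458000 nM and differs from the others in more than one place. Compound 2 (`CC1(/C=C/c2ccccc2C(F)(F)F)C=CC(=O)O1`) stands at 12700 nM and holds the lowest of the three numbers, which makes it the strongest inhibitor of growth so far.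

Within the data shown here, the next compound is compound 4 (`CC1(/C=C/c2ccccc2O)C=CC(=O)O1`), with hydroxy in place of trifluoromethyl on an aromatic carbon as the single change from compound 2.

Among the measured compounds shown here, one measured step bears on this: a 9.4-fold lower number from compound 1 to compound 2 (0.97 log units; beyond the scatter) for trifluoromethyl in place of hydrogen on an aromatic carbon. That step is modest but beyond the scatter. For the measured compounds named here, no hydroxy compound has been measured, so the standing of hydroxy against hydrogen is open. Losing trifluoromethyl is expected to give back a good part of the gain seen in that step, with the number moving up towards compound 1 at 119000 nM without quite reaching it. The estimated move is a 3.9-fold higher number from compound 2 to compound 4 (0.60 log units; beyond the scatter) in the direction of weaker inhibition of growth. For compound 4 the expected value is 50000 nM with an estimated range from 14000 nM to 180000 nM in this assay once measured.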

Compound 4, concentration for total growth inhibition: 57300 nM
Beside the measured number, compound 4's estimate is 1.1-fold (0.06 log units) below it, within the range that was stated.
By their numbers in this assay, from the lowest: compound 2; then compound 4; then compound 1; then compound 3.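

Read in this assay, the aromatic carbon ortho to a group of 9 heavy atoms now has three substituents to compare across compound 1, compound 2 and compound 4. Hydroxy in place of trifluoromethyl gives a 4.5-fold higher number from compound 2 to compound 4 (0.65 log units; beyond the scatter) and so gives back part of the gain from trifluoromethyl, yet hydroxy does not return the series to the hydrogen compound, since hydroxy in place of hydrogen gives a 2.1-fold lower number from compound 1 to compound 4 (0.32 log units; beyond the scatter) as the smaller of these two steps. The lowering of the number at this place therefore does not belong to trifluoromethyl alone: both substituents lie on the same side of hydrogen, with trifluoromethyl further from it, although the two differ in heavy atoms and in hydrogen-bond counts.

From the compounds shown here alone, with only these three substituents at this place, it remains open where a methoxy group, a chlorine atom, an amine or a carboxylic acid would fall in this order, and whether hydroxy and trifluoromethyl would keep the same order on another carbon of the aromatic ring. Nothing at hand bears on why the substituents fall in this order.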